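This account rests on a few compounds, and the source may have more. Where it says the series, first, only, none or still open, it means among the compounds named here.

Measured compounds:
Compound 1, `CCCCN(C)c1nc(C(F)(F)F)ccc1CNC(=O)C(C)c1ccc(NS(C)(=O)=O)c(F)c1`, gives 0.8 nM in a functional assay on CHO-K1 cells for antagonist activity at transient receptor potential cation channel subfamily V member 1 (Homo sapiens), read by FLIPR; on this read-out higher numbers stand for weaker inhibition and lower numbers for stronger inhibition.
Compound 2, `CC(C(=O)NCc1ccc(C(F)(F)F)nc1N1CCC(C)(C)CC1)c1ccc(NS(C)(=O)=O)c(F)c1`, gives 0.3 nM.
Compound 3, `Cc1ccc(CC2CCN(c3nc(C(F)(F)F)ccc3CNC(=O)C(C)c3ccc(NS(C)(=O)=O)c(F)c3)CC2)cc1`, gives 0.2 nM.

Compound 3 stands at the lowest of the three numbers in this assay, but its gap to compound 2 lies within the scatter, so the two cannot be placed in order; only compound 1 sits beyond the scatter above both. Going by the values given here, the one step computed between measured compounds, a 2.7-fold lower number from compound 1 to compound 2 (0.43 log units; beyond the scatter), came with 4,4-dimethylpiperidin-1-yl in place of butyl(methyl)amino on an aromatic carbon and was modest.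

Compound 4, `CC(C(=O)NCc1ccc(C(F)(F)F)nc1N1CCC(CN(C)C)CC1)c1ccc(NS(C)(=O)=O)c(F)c1`, is not yet measured. It differs from compound 3 in one place: dimethylamino in place of 4-methylphenyl on a saturated chain carbon bound to a saturated ring carbon. Among the compounds with values here, no measured pair shows this change. The comparison of compound 2 with compound 3 indicates that what the saturated ring carries may be altered without a move beyond the scatter, and the step of a 2.7-fold lower number from compound 1 to compound 2 (0.43 log units; beyond the scatter) shows the same region tolerating change. On that basis no step beyond the scatter is expected for compound 4, the estimated change being a 2.0-fold higher number from compound 3 to compound 4 (0.30 log units; within the scatter). The estimated value for compound 4 in this assay is 0.4 nM, with an expected range from 0.15 nM to 1.2 nM.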

Compound 4, inhibition constant: 2.1 nM
Compound 4: middle estimate off by 5.3-fold (0.72 log units), on the low side, outside the stated range (above it).
By their numbers in this assay, from the lowest: compounds 3 and 2 (each within the scatter of the next); then compound 1; then compound 4.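

In this assay, going by these compounds alone, the exchange of 4-methylphenyl for dimethylamino on a saturated chain carbon bound to a saturated ring carbon brings an 11-fold higher number from compound 3 to compound 4 (1.02 log units; beyond the scatter) and is large, so this place is far less forgiving than the earlier compounds suggested. The same group, taken as 4-((dimethylamino)methyl)piperidin-1-yl on an aromatic carbon, also gives a 7.0-fold higher number from compound 2 to compound 4 (0.85 log units; beyond the scatter) and a 2.6-fold higher number from compound 1 to compound 4 (0.42 log units; beyond the scatter), which puts compound 4 beyond the scatter of all three earlier compounds and shows that this region does not accept every change. Nothing in the material at hand accounts for the rise.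

The compounds shown do not separate the arrival of the nitrogen from the departure of the aromatic ring, since the exchange does both at once and also goes from 7 heavy atoms to 3. On these data alone, a cyclohexyl group at this place, or an isopropyl or methoxy group in place of dimethylamino, would bear on that question, and whether a larger amine such as morpholin-4-yl or piperidin-1-yl behaves like dimethylamino also remains open.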